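The compounds below may be only part of what the source reports. "The series", "measured", "known", "first", "only" and "open" are said of these compounds alone.

In a functional assay on ECa-109 cells (Homo sapiens) for inhibition, read by MTT assay, with a stated time of 72 h (a lower number here means a stronger inhibitor, a higher number a weaker inhibitor), compound 3 `O=C(OCc1ccccc1)N1CCN(C(=S)SCc2cn(Cc3ccc(F)cc3)nn2)CC1` gives 32000 nM, the only numerical result among the three measured structures. Compound 1 `Fc1ccc(Cn2cc(CSC(=S)N3CCNCC3)nn2)cc1` in this assay reaches only the limit > 128000 nM. Compound 2 `CC(C)(C)OC(=O)N1CCN(C(=S)SCc2cn(Cc3cc(=O)oc4cc(O)ccc34)nn2)CC1` likewise returns the limit > 128000 nM. For the measured compounds named here, the single measured step, an at least 4.0-fold lower number from compound 1 to compound 3 (0.60 log units; beyond the scatter), is known only as a lower bound because the limit of > 128000 nM in this assay, at which 2 of the 3 values shown sit, caps what compound 1 can show.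

Compound 4 `O=C(OCc1ccccc1)N1CCN(C(=S)SCc2cn(Cc3ccc(Cl)c(Cl)c3)nn2)CC1` differs from compound 3 by 3,4-dichlorophenyl in place of 4-fluorophenyl on a saturated chain carbon bound to an aromatic nitrogen. No measured step touches this part of the core; the one step shown concerns the amine nitrogen in the ring, not the substituted phenyl. The expectation therefore rests on compound 3 alone, and the change is expected to move the number by no more than a 1.5-fold lower number from compound 3 to compound 4 (0.16 log units; within the scatter), within or at the edge of the scatter. Compound 4 is estimated at 22000 nM in this assay, with a range from 6000 nM to 80000 nM.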

Compound 4, half-maximal inhibitory concentration: 29400 nM
Estimate against measurement, compound 4: 1.3-fold (0.13 log units) below; the measured number falls inside the stated range.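

In this assay, this position gives a 1.1-fold lower number from compound 3 to compound 4 (0.04 log units; within the scatter), so 3,4-dichlorophenyl and 4-fluorophenyl on a saturated chain carbon bound to an aromatic nitrogen cannot be told apart here. With the benzyloxycarbonyl group held in place, the exchange leaves the reading within the scatter. This is the only step shown with a number at both ends, whereas the step at the amine nitrogen in a ring has a limit at one end: the limit of > 128000 nM in this assay, at which 2 of the 4 values shown sit.

The compounds shown leave open whether a different group in place of 3,4-dichlorophenyl, such as a pyridine ring, a cyclohexyl ring or a carboxylic acid, would move the number beyond the scatter. Also open, from the compounds shown here alone, is whether an acetyl or a benzoyl group on the amine nitrogen in a ring would match benzyloxycarbonyl.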